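Methyl on the core ring and the ester chain

This account rests on a few compounds, and the source may have more. Where it says the series, first, only, none or still open, it means among the compounds named here.

Compound 1 `CCOC(=O)c1sc2ccccc2c1Nc1cc(OC)c(OC)c(OC)c1` carries an ethoxycarbonyl group on the shared core. In a functional assay on HeLa cells (Homo sapiens) for cytotoxicity, read by MTT assay, with a stated time of 72 h (on this read-out lower numbers stand for stronger inhibition and higher numbers for weaker inhibition), compound 1 gives 3100 nM. Compound 2 `CCOC(=O)c1sc2cc(C)ccc2c1Nc1cc(OC)c(OC)c(OC)c1` differs from it by methyl in place of hydrogen on an aromatic carbon and gives 0.38 nM, a step of an 8200-fold lower number from compound 1 to compound 2 (3.91 log units; beyond the scatter). Compound 3 `COC(=O)c1sc2ccccc2c1Nc1cc(OC)c(OC)c(OC)c1` differs from compound 1 by hydrogen in place of methyl on a saturated chain carbon bound to an oxygen next to a carbonyl group. Compound 3 gives 427 nM, a step of a 7.3-fold lower number from compound 1 to compound 3 (0.86 log units; beyond the scatter). Compound 4 `COC(=O)c1sc2ccc(C)cc2c1Nc1cc(OC)c(OC)c(OC)c1` has not been measured; it differs from compound 3 by methyl in place of hydrogen on an aromatic carbon, the same change as that from compound 1 to compound 2. Compound 4 is expected to give a step of a 430-fold lower number from compound 3 to compound 4 (2.63 log units; beyond the scatter), smaller than the earlier one because an 8200-fold lower number from compound 1 to compound 2 (3.91 log units; beyond the scatter) rests on a single pair and the ester chain of compound 3 differs. Compound 4 is estimated at 1 nM, between 0.05 nM and 20 nM.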

Compound 4, half-maximal inhibitory concentration: 398 nM
Beside the measured number, compound 4's estimate is 400-fold (2.60 log units) below it; measured number above the stated range.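

In this assay, methyl in place of hydrogen on an aromatic carbon gives a 1.1-fold lower number from compound 3 to compound 4 (0.03 log units; within the scatter), so the large step seen on the core of compound 1 does not appear on the core of compound 3. The size of this change therefore did not carry from one core to the other: the same change on two cores in this assay, an 8200-fold lower number (3.91 log units; beyond the scatter) from compound 1 to compound 2 and a 1.1-fold lower number (0.03 log units; within the scatter) from compound 3 to compound 4, 7600-fold (3.88 log units) apart, beyond the scatter of two such steps. This shows that a step read from a single pair cannot be relied on in this series, but two pairs do not show why the steps differ or how the change would behave on any further core.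

The compounds shown leave open how a propyl ester or a carboxylic acid in place of the ester would respond to the same methyl. They also leave open whether chlorine on that aromatic carbon would behave as methyl does.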